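The source may report more compounds than this note shows. Statements on the series, on what has been measured and on what is new or still open speak of the compounds shown alone.

Measured so far:
compound 1, `C[C@@H](NC(=O)c1ccc(C#Cc2cccc(F)c2)cc1)C(C)(C)O`, 53.9%;
compound 2, `C[C@@H](NC(=O)c1ccc(C#Cc2cccc(F)c2)cn1)C(C)(C)C`, 66%.

In a functional assay on HEK293 cells for positive allosteric modulation of metabotropic glutamate receptor 5 (Rattus norvegicus), read by fluorescence and calcium flux (on this read-out higher numbers stand for larger maximal responses and lower numbers for smaller maximal responses), compound 2 gives 66%, the highest of the two numbers recorded; compound 1 gives 53.9%, a gap beyond the usual scatter. The next compound, compound 3 `O=C(NCC1CCC1)c1ccc(C#Cc2cccc(F)c2)cn1`, differs from compound 2 in one place: cyclobutylmethyl in place of 1,2,2-trimethylpropyl on an amide-type nitrogen. Going by the values given here, no measured pair in this set shows the effect of such a change, so its direction in this assay is not known from the data. A step no larger than the scatter is expected, leaning slightly downward, a number 6 percentage points lower from compound 2 to compound 3 (within the scatter). Compound 3 is estimated to give 60%, between 40% and 80%.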

Compound 3, largest response reached (reported as efficacy), in percent of the reference or control that the assay uses: 68.1%
The estimate for compound 3 lay 8.1 percentage points below the measured number; the range from low to high includes it.
By their numbers in this assay, from the lowest: compound 1; then compounds 2 and 3 (each within the scatter of the next).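

In this assay, going by these compounds alone, the step for cyclobutylmethyl in place of 1,2,2-trimethylpropyl on the amide-type nitrogen is a number 2.1 percentage points higher from compound 2 to compound 3 (within the scatter) and gives the first one-place comparison at this position. The read-out therefore does not separate the open-chain group with its defined stereocentre from the four-membered carbon ring, which has one heavy atom fewer. Nothing available explains this result.

Going by these compounds, whether a longer chain on this nitrogen would give a similar response remains open. So does the effect of an amine or a carboxylic acid at the same place.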